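Swapping the chain-end aryl ring in an unmeasured thiazole analogue

A few compounds are considered here, and "the series" means these few. Any claim that something is new, unique, unknown or untested is made for them only; others in the source may bear on it.

Measured compounds in a functional assay on Bel-7402 cells (Homo sapiens) for cytotoxicity, read by MTT assay; a lower number here means a stronger inhibitor, a higher number a weaker inhibitor:
compound 1, `COc1cccc(/C=C/C(=O)c2sc(Nc3cccc(C)c3)nc2C)c1`: > 25000 nM
compound 2, `COc1cccc(/C=C/C(=O)c2sc(Nc3ccc(Cl)cc3)nc2C)c1`: > 25000 nM
compound 3, `COc1cccc(/C=C/C(=O)c2sc(Nc3ccccc3)nc2C)c1`: > 25000 nM

Compound 1 sits at a limit in this assay, with > 25000 nM given as a limit and no number. Compound 2 is also reported only as a limit. Compound 3 likewise stands at a limit. The three steps between them, a step that the two limits leave unreadable from compound 1 to compound 2, a step that the two limits leave unreadable from compound 1 to compound 3 and a step that the two limits leave unreadable from compound 2 to compound 3, therefore cannot be sized, a consequence of the limit of > 25000 nM in this assay, at which 3 of the 3 values shown sit.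

Compound 4, `Cc1cccc(Nc2nc(C)c(C(=O)/C=C/c3ccccc3Cl)s2)c1`, differs from compound 1 by 2-chlorophenyl in place of 3-methoxyphenyl on a double-bonded chain carbon bound to a double-bonded chain carbon. Within the data shown here, none of the measured steps touches this part of the molecule; all of them vary the ring on the nitrogen, so nothing recorded bears directly on this change, and no step size can be read from them in any direction.

With every neighbour at the limit, compound 4 is expected to remain at or near that limit, the expected step from compound 1 being a step that the limit leaves unreadable from compound 1 to compound 4. The estimate for compound 4 in this assay is 30000 nM, within a range from 8000 nM to 100000 nM.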

Compound 4, half-maximal inhibitory concentration: > 25000 nM
Compound 4 ended at the assay's limit; the forecaster's own chance of this, stated with the estimate: 70%; the middle value does not contradict the limit.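

Among these compounds, compound 4, like compound 1, is reported only as a limit, so no step between compound 1 and compound 4 can be read: the limit of > 25000 nM in this assay, at which 4 of the 4 values shown sit. The compounds shown leave open whether any change to the ring on the nitrogen or to the chain-end aryl ring gives a measurable value.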